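The source may hold more compounds than are shown below. What is called first, only, known or untested is meant among the compounds shown, and "the series" means these compounds.

Working notes on the benzoylthiourea series, tested in an ADME assay on Huh-7 cells (Homo sapiens) for cytotoxicity; a lower number here means that less compound is tolerated, a higher number that more compound is tolerated.

Of the compounds shown here, three carry numbers so far. Compound 1 `O=C(NC(=S)N1CCc2ccc(OCc3ccccc3)cc21)c1ccccc1` gives 43800 nM. Compound 2 `O=C(NC(=S)N1CCc2cccc(OCc3ccccc3)c21)c1ccccc1` reaches only the limit of the assay, > 50000 nM, and no number. Compound 3 `O=C(NC(=S)N1CCc2c(OCCCCCOc3ccc(Cl)cc3)cccc21)c1cccc([N+](=O)[O-])c1` gives 12100 nM. Of the two numbers, compound 3 stands lowest; the nearest is compound 1, whose number sits higher by a gap beyond the usual scatter. The limit of compound 2 is noted as a limit only (the limit of > 50000 nM in this assay, at which 1 of the 3 values shown sits).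

The next compound, compound 4 `O=C(NC(=S)N1CCc2c(OCCCCCOc3ccc(Cl)cc3)cccc21)c1ccc(Br)cc1`, keeps the core of compound 3 and changes the benzoyl part: 4-bromophenyl in place of 3-nitrophenyl on a carbonyl carbon. For the measured compounds named here, no pair of measured compounds shares this change, so there is no measured step to lean on. With the core and the pentyl-linked chlorophenoxy side unchanged, the step in this assay from compound 3 to compound 4 is expected to be small, most likely within the scatter, with no firm direction; the expected step is a 1.2-fold higher number from compound 3 to compound 4 (0.09 log units; within the scatter). For compound 4 the estimate in this assay is 15000 nM, with the range from 5000 nM to 45000 nM held wide.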

Compound 4, half-maximal cytotoxic concentration: 29100 nM
Compound 4: middle estimate off by 1.9-fold (0.29 log units), on the low side; the range from low to high includes it.
By their numbers in this assay, from the lowest: compound 3; then compounds 4 and 1 (each within the scatter of the next). At a limit, above all of these: compound 2.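

In this assay, with the core and the pentyl-linked chlorophenoxy side unchanged, 4-bromophenyl in place of 3-nitrophenyl on a carbonyl carbon gives a 2.4-fold higher number from compound 3 to compound 4 (0.38 log units; beyond the scatter), a modest step but beyond the scatter. For the compounds shown here, this is the first step that can be read at a single place, and it shows that the group on the carbonyl carbon can shift the cytotoxicity read-out even when the long side chain stays the same. The data on hand give no measured property that bears on this step, so its cause remains unassigned.

The step swaps both the substituent and its ring position at once, so the contributions of the bromine and of its placement cannot be separated; 3-bromophenyl and 4-nitrophenyl would divide the change into two parts. Also open, as far as these compounds go, is whether the step holds on the other cores or with a shorter chain in place of the pentyl linker, and how an amine or a carboxylic acid on the same phenyl ring would read.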